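A few compounds are considered here, and "the series" means these few. Any claim that something is new, unique, unknown or untested is made for them only; others in the source may bear on it.

Compound 1 `N[C@@H](CCC(=O)OC[C@H]1O[C@@H](n2cc(F)c(=O)[nH]c2=O)C[C@@H]1OC(=O)CC[C@H](N)C(=O)O)C(=O)O` gives 1.13 h
Compound 2 `N[C@@H](CC(=O)OC[C@H]1O[C@@H](n2cc(F)c(=O)[nH]c2=O)C[C@@H]1O)C(=O)O` gives 2.5 h

In an ADME assay on a cell-free system (plasma, Rattus norvegicus) for metabolic stability, read by LC-MS, with a stated time of 120 min, tested at 200 uM (a higher number here means that the compound lasts longer, a lower number that the compound disappears faster), compound 2 stands highest of the two measured compounds, clearly beyond the scatter from compound 1. Compound 3 `N[C@@H](CC(=O)OC[C@H]1O[C@@H](n2cc(F)c(=O)[nH]c2=O)C[C@@H]1OC(=O)C[C@H](N)C(=O)O)C(=O)O` has (2-amino-2-carboxyethyl)carbonyl in place of hydrogen on an oxygen on a saturated carbon, which counts as (2-amino-2-carboxyethyl)carbonyl in place of hydrogen on an oxygen on a saturated carbon in full. Among the measured compounds shown here, no single-change step has been measured, so the best guide is compound 1 with 1.13 h as it also carries two amino acid chains. A fall beyond the scatter is expected, an estimated 2.1-fold lower number from compound 2 to compound 3 (0.32 log units; beyond the scatter) in this assay overall. For compound 3 the expected half-life is 1.2 h within a range of 0.6 h to 2.4 h as an estimate.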

Compound 3, half-life: 0.935 h
For compound 3 the middle estimate is 1.3-fold (0.11 log units) above the measured one, and the stated range covers the measured number.
By their numbers in this assay, from the lowest: compounds 3 and 1 (each within the scatter of the next); then compound 2.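

In this assay the change from hydroxy to ((2-amino-2-carboxyethyl)carbonyl)oxy brings a 2.7-fold lower number from compound 2 to compound 3 (0.43 log units; beyond the scatter) in half-life, a modest step but beyond the scatter. This oxygen on a saturated carbon is therefore not a neutral place to add this chain: with the chain in place of hydrogen, the compound disappears faster. Nothing measured here gives a reason for this fall.

As far as these compounds go, it remains open whether a plain acetyl on this oxygen, with no amine or carboxylic acid, would shorten the half-life as much.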